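A few compounds are considered here, and "the series" means these few. Any claim that something is new, unique, unknown or untested is made for them only; others in the source may bear on it.

Measured in a functional assay on HeLa cells (Homo sapiens) for inhibition, read by MTT assay, with a stated time of 72 h; a lower number here means a stronger inhibitor, a higher number a weaker inhibitor:
- Compound 1 `COc1ccc(/C=C/C(=O)c2c(OC)cc(O)c(CC=C(C)C)c2O)cc1`: > 50000 nM, a limit of the assay, not a number
- Compound 2 `COc1cc(/C=C/C(=O)c2c(OC)cc(O)c(CC=C(C)C)c2O)ccc1O`: 33800 nM
- Compound 3 `COc1cc(O)c(CC=C(C)C)c(O)c1C(=O)/C=C/c1ccc(O)c(O)c1`: 38100 nM

Only compound 2 and compound 3 give numbers, and these two sit together, with a 1.1-fold higher number from compound 2 to compound 3 (0.05 log units; within the scatter). Compound 2 therefore has no separation from compound 3, and both are weak inhibitors in this assay.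

The next step leads to compound 4 `COc1ccccc1/C=C/C(=O)c1c(OC)cc(O)c(CC=C(C)C)c1O`: 2-methoxyphenyl in place of 4-hydroxy-3-methoxyphenyl on a double-bonded chain carbon bound to a double-bonded chain carbon. In words, 2-methoxyphenyl stands in place of 4-hydroxy-3-methoxyphenyl on a double-bonded chain carbon bound to a double-bonded chain carbon.

The closest measured comparison is compound 1, whose 4-methoxyphenyl likewise carries a methoxy and no hydroxy. Its > 50000 nM is a limit. Among the compounds with values here, the steps that bear on the change are an at least 1.4-fold lower number from compound 1 to compound 2 (0.17 log units; that floor lies within the scatter) and an at least 1.3-fold lower number from compound 1 to compound 3 (0.11 log units; that floor lies within the scatter). Within the data shown here, both are floors only, so the true size of these steps stays open, and no measured compound has the methoxy at the 2-position of the phenyl.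

A small move towards a higher number is therefore expected, not clearly beyond the scatter, and a report of a limit alone would be no surprise. The expected step is a 1.2-fold higher number from compound 2 to compound 4 (0.09 log units; within the scatter). For compound 4 the estimated value is 42000 nM, with an expected range of 20000 nM to 75000 nM.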

Compound 4, half-maximal inhibitory concentration: 19700 nM
Beside the measured number, compound 4's estimate is 2.1-fold (0.33 log units) above it; measured number outside the range, below it.
By their numbers in this assay, from the lowest: compounds 4, 2 and 3 (each within the scatter of the next). At a limit, above all of these: compound 1.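

In this assay, within the data shown here, 2-methoxyphenyl in place of 4-methoxyphenyl on the double-bonded chain carbon gives an at least 2.5-fold lower number from compound 1 to compound 4 (0.40 log units; beyond the scatter), the only step so far printed as beyond the scatter, and it is a floor rather than a full size. Compound 1 stands at a limit of the assay, not a number: the limit of > 50000 nM in this assay, at which 1 of the 4 values shown sits. Against the hydroxy-bearing rings, the same 2-methoxyphenyl gives a 1.7-fold lower number from compound 2 to compound 4 (0.23 log units; within the scatter) and a 1.9-fold lower number from compound 3 to compound 4 (0.29 log units; within the scatter), so a ring with no hydroxy can sit in the same range as those rings, which compound 1 alone did not show.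

Open, as far as these compounds go, is whether this range depends on a methoxy specifically in the form of 2-methoxyphenyl, or whether a 2-hydroxyphenyl, a 2-ethoxyphenyl or a 2-aminophenyl on the same chain carbon would behave alike. Also open, from the compounds shown here alone, are the true size of the step from compound 1 and whether any change at this place can move the series well clear of the range that compound 2, compound 3 and compound 4 share in this assay.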